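Aryl imine series on a shared core: outlook for compound 4

The compounds below may be only part of what the source reports. "The series", "measured", "known", "first", "only" and "open" are said of these compounds alone.

The three measured compounds share one core bearing an aryl imine and differ only in the aryl substitution; all were tested in a functional assay on P388 cells (Mus musculus) for cytotoxicity, read by MTT assay, with a stated time of 72 h; a lower number here means a stronger inhibitor, a higher number a weaker inhibitor. Compound 1 `Cc1c(/N=C/c2ccc(N(C)C)cc2)c(=O)n(-c2ccccc2)n1C` gives 468000000 nM. Compound 2 `CCOc1cccc(/C=N/c2c(C)n(C)n(-c3ccccc3)c2=O)c1` gives 295000000 nM, and compound 3 `COc1ccccc1/C=N/c1c(C)n(C)n(-c2ccccc2)c1=O` gives 229000000 nM. Compound 1 holds the highest number of the three; its nearest neighbour is compound 2, whose number lies within the scatter of it, and the furthest is compound 3, whose number lies beyond the scatter of it. All three numbers sit in the same very weak region of this assay.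

Compound 4 `Cc1c(/N=C/c2ccc(Cl)cc2)c(=O)n(-c2ccccc2)n1C` has not yet been measured. It differs from compound 1 by chloro in place of dimethylamino on an aromatic carbon. Among the measured compounds shown here, no step between measured compounds covers this change, so the measured set gives no direct guide to its effect. Since every measured aryl variant lands in the same weak region, the step is expected to be small, a 1.6-fold lower number from compound 1 to compound 4 (0.19 log units; within the scatter), with no direction claimed beyond the scatter. Compound 4 is therefore estimated at 300000000 nM in this assay, within a range of 120000000 nM to 750000000 nM.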

Compound 4, half-maximal inhibitory concentration: 646000000 nM
For compound 4 the middle estimate is 2.2-fold (0.33 log units) below the measured one; the range from low to high includes it.
By their numbers in this assay, from the lowest: compounds 3, 2, 1 and 4 (each within the scatter of the next, the first and the last beyond it).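

In this assay, among the compounds shown here, chloro in place of dimethylamino on an aromatic carbon, para to a large group, gives a 1.4-fold higher number from compound 1 to compound 4 (0.14 log units; within the scatter) and so leaves no readable effect of this exchange at this position. 4-Chlorophenyl in place of 2-methoxyphenyl on a carbon with a double bond to nitrogen gives a 2.8-fold higher number from compound 3 to compound 4 (0.45 log units; beyond the scatter) and is the first step to clear the scatter, although it is modest and all the numbers remain in the same very weak region. No measured evidence bears on these steps. Going by these compounds, whether a carboxylic acid or a hydroxyl group at the same aromatic carbon would lift a compound out of this weak region remains open. Also open, on these data alone, is how far a change to the shared core itself, rather than to the aryl group, would move the number.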